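Adding a Bromine to Two Related Antiproliferative Cores

This account rests on a few compounds, and the source may have more. Where it says the series, first, only, none or still open, it means among the compounds named here.

Measured so far, in a functional assay on A549 cells (Homo sapiens) for antiproliferative activity, read by MTT assay, with a stated time of 72 h; on this read-out higher numbers stand for weaker inhibition and lower numbers for stronger inhibition:
compound 1, `O=C1NC(=O)/C(=C/C2=Cc3ccccc3OC2)S1`, gives 192000 nM
compound 2, `O=C1NC(=S)S/C1=C\C1=Cc2ccccc2OC1`, gives 73100 nM
compound 3, `O=C1NC(=O)/C(=C/C2=Cc3cc(Br)ccc3OC2)S1`, gives 79500 nM

Compound 3 is compound 1 with one change, (bromo in place of hydrogen on an aromatic carbon). That change gave a 2.4-fold lower number from compound 1 to compound 3 (0.38 log units; beyond the scatter). Compound 2 has a different core from compound 1; the difference between the two cores is not broken down here. In this assay compound 2 and compound 3 lie within the usual scatter of each other, so no order between them can be read from these numbers.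

Compound 4, `O=C1NC(=S)S/C1=C\C1=Cc2cc(Br)ccc2OC1`, has not yet been measured. It stands to compound 2 as compound 3 stands to compound 1: the change is bromo in place of hydrogen on an aromatic carbon, at the same place in the same words. This is the same change, made on the second core.

Among the measured compounds shown here, the expectation for compound 4 rests on the one measured instance of this change, a 2.4-fold lower number from compound 1 to compound 3 (0.38 log units; beyond the scatter), and on compound 2 giving 73100 nM. On that basis the estimated step is a 2.4-fold lower number from compound 2 to compound 4 (0.37 log units; beyond the scatter), with the step on the second core taken to be about as large as on the first. Compound 4 is therefore expected to give about 31000 nM in this assay, estimated to fall between 14000 nM and 65000 nM.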

Compound 4, half-maximal inhibitory concentration: 51000 nM
Compound 4: middle estimate off by 1.6-fold (0.22 log units), on the low side; low and high end bracket the measured number.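

In this assay, putting bromo in place of hydrogen on an aromatic carbon of the second core gave a 1.4-fold lower number from compound 2 to compound 4 (0.16 log units; within the scatter), a step too small to separate from the ordinary spread of repeated measurements. Set beside the earlier step, the two cores cannot be told apart in how they respond to this change: the same change on two cores in this assay, a 2.4-fold lower number (0.38 log units; beyond the scatter) from compound 1 to compound 3 and a 1.4-fold lower number (0.16 log units; within the scatter) from compound 2 to compound 4, 1.7-fold (0.23 log units) apart, within the scatter of two such steps. Among the compounds shown here, this shows that the change can be carried from one core to the other without a detectable difference in step size, but it does not show that the steps are truly equal, or that bromo has a real effect on the second core, as each core offers only one comparison and only the step on the first lies beyond the scatter.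

Bromo at this one place is the only replacement for hydrogen among these compounds. Going by these compounds, whether chloro, methoxy, an amine or a carboxylic acid at the same place would behave alike on both cores remains open.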